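Adding a Methyl Next to the Hydroxamic Acid

The source may hold more compounds than are shown below. What is called first, only, known or untested is meant among the compounds shown, and "the series" means these compounds.

Of the compounds shown here, three sharing one core have been measured in a physicochemical assay for lipophilicity; a higher number here means a more lipophilic compound, a lower number a more polar compound. Compound 1 `O=C(NC1(C(=O)NO)CCCCC1)c1ccc(C#Cc2ccccc2)cc1` returns a value that is a limit of the assay rather than a number, namely > 3. Compound 2 `NC(=O)C[C@H](NC(=O)c1ccc(C#Cc2ccccc2)cc1)C(=O)NO` gives a plain reading of 1. Compound 3 `CC(NC(=O)c1ccc(C#Cc2ccccc2)cc1)C(=O)NO` also returns a limit and not a number, > 3. That puts compound 3 at the limit of > 3 in this assay, at which 2 of the 3 values shown sit, so only a lower bound for it is known, and the gap to compound 2 cannot be given a size.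

Compound 4 `CC(C)(NC(=O)c1ccc(C#Cc2ccccc2)cc1)C(=O)NO` differs from compound 3 in one place: methyl in place of hydrogen on a saturated chain carbon bound to an amide-type nitrogen, a carbonyl carbon and a saturated chain carbon. For the measured compounds named here, no measured pair shows this change, so no size for the step can be read from the data. Since compound 3 already sits at a limit with > 3, the expectation is that any shift in this assay for compound 4 would not be seen as a number, and the change is estimated to read a step that the limit leaves unreadable from compound 3 to compound 4. Compound 4 is expected to reach 3.5, within a range from 3 to 4, most likely again reported only as a limit.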

Compound 4, distribution coefficient: 3
For compound 4 the middle estimate is 0.50 log units above the measured one, and the stated range covers the measured number.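

In this assay compound 3 gives > 3, which is a limit of the assay and not a number. With 1-(hydroxycarbamoyl)-1-methylethyl where compound 3 carries 1-(hydroxycarbamoyl)ethyl, compound 4 gives 3, a plain reading, so this position now has a real number attached to it. Methyl in place of hydrogen here gives a number no higher from compound 3 to compound 4 (the limit leaves the size open), and its size stays open because one side of the step is a limit: the limit of > 3 in this assay, at which 2 of the 4 values shown sit.

The compounds shown leave open how the reading in this assay would respond to a longer chain, an amine or a carboxylic acid at this same place. Also open, as far as these compounds go, is how large the methyl step is, which would take a plain number for compound 3.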